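This account rests on a few compounds, and the source may have more. Where it says the series, first, only, none or still open, it means among the compounds named here.

Measured so far:
compound 1, `CC1(c2ccccc2)CC(=O)N(CC(=O)N2CCN(c3ccccc3F)CC2)C1=O`: 300 mg/kg
compound 2, `Cc1cccc(N2CCN(C(=O)CN3C(=O)CC(C)(c4ccccc4)C3=O)CC2)c1`: "not active" (no number reported)

In a functional assay on the whole organism (strain CD-1) with Mus musculus as the target, with a stated time of 2 h (a lower number here means that less compound is needed, a higher number that more compound is needed for the effect), compound 1 gives 300 mg/kg. In this assay, going by the values given here, compound 2 gives "not active" (no number reported), so compound 2 stands without a number and no step from it can be sized. Compound 3, `CC1(c2ccccc2)CC(=O)N(CC(=O)N2CCN(c3cccc(Cl)c3)CC2)C1=O`, differs from compound 2 in one place: chloro in place of methyl on an aromatic carbon. Since compound 2 has no number, neither the size nor the direction of this step can be set from the data; a reported dose of the order seen for compound 1, or again no number, are both open. Compound 3 is expected near 300 mg/kg in this assay, in the range 100 mg/kg to 1000 mg/kg.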

Compound 3, minimum effective dose: "not active" (no number reported)
Compound 3 has no reported number here, so the estimate cannot be set against anything.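

Going by these compounds alone, compound 2 and compound 3 both stand without a number, so no step between them can be read. No supporting data bear on this result. Going by these compounds, whether 3-methylphenyl and 3-chlorophenyl differ in effect remains open.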